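The source may report more compounds than this note shows. Statements on the series, on what has been measured and on what is new or still open speak of the compounds shown alone.

Of the compounds shown here, three built on one shared core have been tested for cytotoxicity in an ADME assay on HEK293 cells (Homo sapiens) for cytotoxicity, read by MTT assay, with a stated time of 72 h; a lower number here means a stronger inhibitor, a higher number a weaker inhibitor. Compound 1 `COc1ccc(OC)c(C2=C(c3cc(OC)c(OC)c(OC)c3)C(=O)CC2O[SiH2]C(C)(C)C)c1` gives 9.5 ug/mL. Compound 2 `COC(=O)c1cc(C2=C(c3cc(OC)c(OC)c(OC)c3)C(=O)CC2O[SiH2]C(C)(C)C)ccc1OC` reaches only a limit of the assay, > 100 ug/mL. Compound 3 `COc1cc(C2=C(c3ccccc3)C(O[SiH2]C(C)(C)C)CC2=O)cc(OC)c1OC` also reaches only a limit of the assay, > 100 ug/mL. Compound 3 therefore stands at the weak end of what has been seen: no number is reported for it, and compound 2 shares that position, as the limit of > 100 ug/mL in this assay, at which 2 of the 3 values shown sit, records. From compound 1 both measured steps run up to that limit, an at least 10-fold higher number from compound 1 to compound 2 (1.02 log units; beyond the scatter) and an at least 10-fold higher number from compound 1 to compound 3 (1.02 log units; beyond the scatter). Between the two limit values the step is a step that the two limits leave unreadable from compound 2 to compound 3.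

Compound 4 `COc1cc(C2=C(c3cc(C)c(OC)c(C)c3)C(O[SiH2]C(C)(C)C)CC2=O)cc(OC)c1OC` is the next compound to be measured in this assay. It differs from compound 3 in one place: 4-methoxy-3,5-dimethylphenyl in place of phenyl on a double-bonded ring carbon. The step that bears most directly on this change is an at least 10-fold higher number from compound 1 to compound 3 (1.02 log units; beyond the scatter), where phenyl in place of 2,5-dimethoxyphenyl moved the number beyond the limit. Compound 4 brings a methoxy-bearing ring back, yet compound 2, which carries 4-methoxy-3-(methoxycarbonyl)phenyl, also sits at the limit, so the return of a methoxy group does not by itself secure a stronger number. The expected step is an at least 1.2-fold lower number from compound 3 to compound 4 (0.09 log units; that floor lies within the scatter), and a limit is again the likelier outcome. Compound 4 is estimated at 80 ug/mL, within a range from 20 ug/mL to 200 ug/mL.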

Compound 4, half-maximal inhibitory concentration: 29 ug/mL
Compound 4: the middle estimate sits 2.8-fold (0.44 log units) above what was measured, and the stated range covers the measured number.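

In this assay, for the compounds shown here, 4-methoxy-3,5-dimethylphenyl is the first group other than 2,5-dimethoxyphenyl on this double-bonded ring carbon to give a real number rather than a limit, so a measurable effect here does not depend on that one ring alone. Placing it where phenyl stood gives an at least 3.4-fold lower number from compound 3 to compound 4 (0.53 log units; beyond the scatter), and placing it where 4-methoxy-3-(methoxycarbonyl)phenyl stood gives an at least 3.4-fold lower number from compound 2 to compound 4 (0.53 log units; beyond the scatter), both only floors because each starts from a limit: the limit of > 100 ug/mL in this assay, at which 2 of the 4 values shown sit. The new group still does not match 2,5-dimethoxyphenyl, as the comparison with the best compound shows a 3.1-fold higher number from compound 1 to compound 4 (0.48 log units; beyond the scatter), so it brings back part of the lost strength but not all of it.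

Which part of 4-methoxy-3,5-dimethylphenyl carries the change remains open, as its methoxy group and its two methyl groups enter together in compound 4. Also open is how the number in this assay would respond to an amine or a carboxylic acid on this ring, since the compounds shown carry neither.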